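This account rests on a few compounds, and the source may have more. Where it says the series, first, only, none or still open, it means among the compounds named here.

Measured compounds:
Compound 1, `C#CCNC1CCc2c(SCc3cccc(C)c3)cccc21`: > 100000 nM
Compound 2, `C#CCNC1CCc2c(SCCc3ccc(F)c(F)c3)cccc21`: "not determined" (no result reported)

In an ADME assay on isolated protein for inhibition of Amine oxidase [flavin-containing] B (Homo sapiens) (a lower number here means a stronger inhibitor, a higher number a weaker inhibitor), compound 1 gives > 100000 nM, which is a limit of the assay and not a number. Compound 1 thus sits at the limit of > 100000 nM in this assay, at which 1 of the 2 values shown sits. For compound 2 the result is "not determined" (no result reported). Compound 3, `C#CCNC1CCc2c(SCc3cccc(C(F)(F)F)c3)cccc21`, has not been measured yet; its change from compound 1 is trifluoromethyl in place of methyl on an aromatic carbon. Going by the values given here, no measured step exists to lean on, so in this assay a step of no more than the usual scatter, in no clear direction, is expected. Compound 3 is expected to give around 100000 nM, somewhere between 20000 nM and 500000 nM, an expected step of a number no higher from compound 1 to compound 3 (the limit leaves the size open).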

Compound 3, half-maximal inhibitory concentration: 7710 nM
Estimate against measurement, compound 3: 13-fold (1.11 log units) above; measured number below the stated range.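

In this assay, this aromatic carbon proves sensitive to what it carries: trifluoromethyl in place of methyl gives an at least 12-fold lower number from compound 1 to compound 3 (1.11 log units; beyond the scatter). As far as these compounds go, compound 1 stands at a limit of the assay, not at a number, so the true size of this step stays open: the limit of > 100000 nM in this assay, at which 1 of the 3 values shown sits. The compounds shown leave open why this change matters, and whether it is specific to trifluoromethyl. A chlorine atom, a nitrile or a methoxy group on the same carbon would show whether other groups give a similar result.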